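Adding a Second Methoxy to Compound 3

The compounds below may be only part of what the source reports. "The series", "measured", "known", "first", "only" and "open" are said of these compounds alone.

In a functional assay on MDA-MB-231 cells (Homo sapiens) for antiproliferative activity, read by MTT assay, with a stated time of 72 h (a higher number here means a weaker inhibitor, a lower number a stronger inhibitor), compound 1 `CCn1ccnc1-c1cc(OC)c(OC)c(OC)c1`, which carries an ethyl on an aromatic nitrogen, gives > 100000 nM. That value is a limit, not a number. Compound 2 `COc1cc(-c2nccn2-c2ccc(C)cc2)cc(OC)c1OC` carries 4-methylphenyl there and gives 4100 nM. Compound 3 `COc1cccc(-n2ccnc2-c2cc(OC)c(OC)c(OC)c2)c1` carries 3-methoxyphenyl and gives 18300 nM, the higher of the two true numbers and so the weaker result. Replacing the ethyl was a large change in one case, an at least 24-fold lower number from compound 1 to compound 2 (1.38 log units; beyond the scatter), and an at least modest one in the other, an at least 5.4-fold lower number from compound 1 to compound 3 (0.73 log units; beyond the scatter). Exchanging one ring for the other was modest, a 4.5-fold higher number from compound 2 to compound 3 (0.65 log units; beyond the scatter).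

Compound 4 `COc1cc(OC)cc(-n2ccnc2-c2cc(OC)c(OC)c(OC)c2)c1` differs from compound 3 by methoxy in place of hydrogen on an aromatic carbon, meta to a methoxy group. Going by the values given here, no measured step adds a group in this way. The closest guide is the modest 4.5-fold higher number from compound 2 to compound 3 (0.65 log units; beyond the scatter), so the expected step is small, a 1.2-fold lower number from compound 3 to compound 4 (0.09 log units; within the scatter), with no change beyond the scatter and no firm direction. For compound 4 the estimated value is 15000 nM, with an expected range from 5000 nM to 50000 nM.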

Compound 4, half-maximal inhibitory concentration: 45200 nM
Beside the measured number, compound 4's estimate is 3.0-fold (0.48 log units) below it, within the range that was stated.
By their numbers in this assay, from the lowest: compound 2; then compound 3; then compound 4. At a limit, above all of these: compound 1.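

The earlier steps shown here each exchanged the whole group on the aromatic nitrogen, whereas this one keeps the 3-methoxyphenyl ring and changes a single place on it, an aromatic carbon meta to a methoxy group. In this assay, methoxy in place of hydrogen there gives a 2.5-fold higher number from compound 3 to compound 4 (0.39 log units; beyond the scatter), so this small addition weakens the result by more than the usual scatter instead of leaving it unchanged. Nothing measured in this set accounts for that loss.

The compounds shown leave open whether a hydroxyl, a fluorine or an amine on this same aromatic carbon would also raise the number, or would lower it. They also leave open whether adding methoxy to the 4-methylphenyl ring of compound 2 would shift the number in the same direction.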